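This account rests on a few compounds, and the source may have more. Where it says the series, first, only, none or still open, it means among the compounds named here.

Compound 1, `O=C1Nc2ccccc2/C1=N/NC(=S)Nc1ccccc1`: in an ADME assay on RD cells (Homo sapiens) for cytotoxicity (a lower number here means that less compound is tolerated, a higher number that more compound is tolerated), compound 1 gives > 25000 nM, which is a limit of the assay and not a number.
Compound 2, `COc1cccc(NC(=S)N/N=C2\C(=O)Nc3ccccc32)c1`: in this assay compound 2 gives > 25000 nM, again a limit.
Compound 3, `O=C1Nc2ccc(OC(F)(F)F)cc2/C1=N/NC(=S)Nc1ccccc1`: in this assay compound 3 gives > 25000 nM, again a limit.

For the measured compounds named here, compound 1 therefore stands only at a limit of this assay, with no number of its own, and the limit of > 25000 nM in this assay, at which 3 of the 3 values shown sit, shows that the same holds for every value measured so far. Compound 4, `CCN1C(=O)/C(=N\NC(=S)Nc2ccccc2)c2ccccc21`, differs from compound 1 in one place: ethyl in place of hydrogen on an amide-type nitrogen in a ring. Two measured steps start from compound 1 and could be compared, a step that the two limits leave unreadable from compound 1 to compound 2 and a step that the two limits leave unreadable from compound 1 to compound 3, but both run between limits and their size cannot be read; both also change an aromatic carbon rather than the amide-type nitrogen in a ring changed here. Nothing measured thus points to a step beyond the scatter in either direction, and the step expected from the ethyl is a step that the limit leaves unreadable from compound 1 to compound 4. Compound 4 is estimated at 40000 nM, with a range from 15000 nM to 100000 nM, and most likely reported once more only as a limit.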

Compound 4, half-maximal cytotoxic concentration: > 25000 nM
Compound 4 gave a limit, no number (the forecaster's own chance of this, stated with the estimate: 80%); the middle value does not contradict the limit.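

Compound 4 also stands only at a limit and not a number, so the step from compound 1 to compound 4 cannot be read, and no new step emerges: the limit of > 25000 nM in this assay, at which 4 of the 4 values shown sit.

The compounds shown leave open what the half-maximal cytotoxic concentration of any of them is in this assay, and whether the ethyl, methoxy or trifluoromethoxy changes it.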